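From pyridin-3-yl to pyridin-4-yl: a step behind a limit

This account rests on a few compounds, and the source may have more. Where it says the series, first, only, none or still open, it means among the compounds named here.

Compound 1 `Cn1cc(C(=O)Nc2ccc(-c3ccccc3)c(C(F)(F)F)c2)c(=O)c2ccccc21` and compound 2 `Cn1cc(C(=O)Nc2ccc(-c3cccnc3)c(C(F)(F)F)c2)c(=O)c2ccccc21` share one core and differ in a single group. In a physicochemical assay for solubility, in phosphate buffer, at pH 7.4 (a higher number here means a more soluble compound, a lower number a less soluble compound), compound 1 gives < 1 ug/mL as a limit of the assay, not a number. In this assay compound 2 gives < 1 ug/mL as a limit too, again not a number. Compound 2 therefore has no number to start from, and the limit of < 1 ug/mL in this assay, at which 2 of the 2 values shown sit, is all that the measurements offer.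

Compound 3 `Cn1cc(C(=O)Nc2ccc(-c3ccncc3)c(C(F)(F)F)c2)c(=O)c2ccccc21` has the same atoms as compound 2, joined differently, and pyridin-4-yl in place of pyridin-3-yl on an aromatic carbon is the whole change: pyridin-4-yl in place of pyridin-3-yl on an aromatic carbon, ortho to a trifluoromethyl group.

Going by the values given here, only one measured step bears on this, and a step that the two limits leave unreadable from compound 1 to compound 2 is that step, with pyridin-3-yl in place of phenyl. It offers no size and no direction to carry over, so in this assay no step beyond the scatter is expected. In numbers, the expected change is a step that the limit leaves unreadable from compound 2 to compound 3 and no more. Compound 3 is estimated at 0.7 ug/mL with an expected range from 0.3 ug/mL to 2 ug/mL in this measurement, and it may well be reported as a limit again.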

Compound 3, solubility: 7.9 ug/mL
Beside the measured number, compound 3's estimate is 11-fold (1.05 log units) below it; the measured number lies above the stated range.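

In this assay, with the same atoms joined differently, pyridin-4-yl in place of pyridin-3-yl gives an at least 7.9-fold higher number from compound 2 to compound 3 (0.89 log units; beyond the scatter), and pyridin-4-yl in place of phenyl gives an at least 7.9-fold higher number from compound 1 to compound 3 (0.89 log units; beyond the scatter). So at this position, ortho to a trifluoromethyl group and para to a large group, the place of the nitrogen within the ring makes a difference beyond the scatter, something the earlier pair could not show, since the step between phenyl and pyridin-3-yl cannot be read. Both new steps are minimum sizes rather than exact ones because each starts from a value that is a limit of the assay, not a number: the limit of < 1 ug/mL in this assay, at which 2 of the 3 values shown sit.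

How far compound 1 and compound 2 truly lie from compound 3 stays unknown, and with only these three groups at this position, the compounds shown cannot tell whether the higher number belongs to pyridin-4-yl alone. Also open, going by these compounds, is what a pyridin-4-yl ring carrying an amine or a methyl group, or a pyrimidine ring in its place, would give in this assay.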